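Aryl variation on the ring nitrogen: compound 4

This account rests on a few compounds, and the source may have more. Where it says the series, first, only, none or still open, it means among the compounds named here.

The three measured compounds share one core and differ only in the aryl group on the aromatic nitrogen. Compound 1 `COc1cc2c(Oc3ccc(NC(=O)c4nn(-c5cccc(F)c5)c(=O)c5ccccc45)cc3F)ccnc2cc1OCCCN1CCCC1` gives 160 nM in a functional assay on MKN-45 cells (Homo sapiens) for cytotoxicity, read by MTT assay, with a stated time of 72 h; a lower number here means a stronger inhibitor, a higher number a weaker inhibitor. Compound 2 `COc1cc2c(Oc3ccc(NC(=O)c4nn(-c5ccccc5F)c(=O)c5ccccc45)cc3F)ccnc2cc1OCCCN1CCCC1` gives 140 nM. Compound 3 `COc1cc2c(Oc3ccc(NC(=O)c4nn(-c5ccccc5Br)c(=O)c5ccccc45)cc3F)ccnc2cc1OCCCN1CCCC1` gives 410 nM. Compound 3 stands highest of the three numbers: a 2.6-fold higher number from compound 1 to compound 3 (0.41 log units; beyond the scatter) and a 2.9-fold higher number from compound 2 to compound 3 (0.47 log units; beyond the scatter), while a 1.1-fold lower number from compound 1 to compound 2 (0.06 log units; within the scatter).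

Compound 4 `COc1ccc(-n2nc(C(=O)Nc3ccc(Oc4ccnc5cc(OCCCN6CCCC6)c(OC)cc45)c(F)c3)c3ccccc3c2=O)cc1` differs from compound 3 by 4-methoxyphenyl in place of 2-bromophenyl on an aromatic nitrogen. For the measured compounds named here, the steps that bear on this change are the two into compound 3, a 2.6-fold higher number from compound 1 to compound 3 (0.41 log units; beyond the scatter) and a 2.9-fold higher number from compound 2 to compound 3 (0.47 log units; beyond the scatter), both modest rises on bringing in the bromo-bearing aryl group. Going by the values given here, no measured compound carries a 4-methoxyphenyl, so there is no direct precedent for the entering group. What the data show is that compound 3 is the outlier among three aryl variants and that the two fluorophenyl compounds sit close together. On that basis the step is estimated as a 2.1-fold lower number from compound 3 to compound 4 (0.31 log units; beyond the scatter), a modest fall back toward the range of compound 1 and compound 2. Compound 4 is expected at 200 nM, with a range from 80 nM to 500 nM.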

Compound 4, half-maximal inhibitory concentration: 1320 nM
Estimate against measurement, compound 4: 6.6-fold (0.82 log units) below, outside the stated range (above it).
By their numbers in this assay, from the lowest: compounds 2 and 1 (each within the scatter of the next); then compound 3; then compound 4.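

In this assay, 4-methoxyphenyl on the aromatic nitrogen gives the highest number of the four aryl variants: a 3.2-fold higher number from compound 3 to compound 4 (0.51 log units; beyond the scatter), so this change moves further from the two fluorophenyl compounds rather than back toward them. The steps from those two compounds, a 9.4-fold higher number from compound 2 to compound 4 (0.97 log units; beyond the scatter) and an 8.3-fold higher number from compound 1 to compound 4 (0.92 log units; beyond the scatter), are larger than any step among compounds 1, 2 and 3, which shows that the number at this position can shift much further than those three compounds suggested. Nothing available accounts for this rise.

The compounds shown do not separate the effect of the methoxy group from that of where it sits on the phenyl ring. As far as these compounds go, it also remains open whether an unsubstituted phenyl, or a phenyl carrying an amine or a carboxylic acid, would fall near the fluorophenyl compounds or near compound 4.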